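This account rests on a few compounds, and the source may have more. Where it says the series, first, only, none or still open, it means among the compounds named here.

In an ADME assay on C8166 cells (Homo sapiens) for cytotoxicity, read by MTT assay (a higher number here means that more compound is tolerated, a lower number that less compound is tolerated), three close relatives have been measured so far. Compound 1 `Cc1cc(S(N)(=O)=O)ccc1NC(=O)COc1ccc(Cl)cc1C(O)c1cccc(C)c1C` gives 218000 nM, compound 2 `Cc1ccc(C(O)c2cc(Cl)ccc2OCC(=O)Nc2ccc(S(N)(=O)=O)cc2C)c(C)c1` gives 26400 nM, and compound 3 `Cc1ccc(C)c(C(O)c2cc(Cl)ccc2OCC(=O)Nc2ccc(S(N)(=O)=O)cc2C)c1` gives 35500 nM. On these numbers, compound 3 stands level with compound 2 and well under compound 1.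

Compound 4 `Cc1cc(C)cc(C(O)c2cc(Cl)ccc2OCC(=O)Nc2ccc(S(N)(=O)=O)cc2C)c1` has the same atoms as compound 3, joined differently. It carries 3,5-dimethylphenyl in place of 2,5-dimethylphenyl on a saturated chain carbon bound to an aromatic carbon and an oxygen on a saturated carbon.

The measured steps that bear on this are the other swaps of the same dimethylphenyl group. They run from a 1.3-fold higher number from compound 2 to compound 3 (0.13 log units; within the scatter) up to an 8.3-fold lower number from compound 1 to compound 2 (0.92 log units; beyond the scatter) and a 6.1-fold lower number from compound 1 to compound 3 (0.79 log units; beyond the scatter). So such a swap can do almost nothing or shift the number clearly, and no measured compound carries 3,5-dimethylphenyl.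

The expected change is small, a slightly higher number that stays within the scatter: a 1.4-fold higher number from compound 3 to compound 4 (0.15 log units; within the scatter). For compound 4 the estimated value is 50000 nM, with an expected range from 18000 nM to 180000 nM.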

Compound 4, half-maximal cytotoxic concentration: 29400 nM
Beside the measured number, compound 4's estimate is 1.7-fold (0.23 log units) above it; the range from low to high includes it.
By their numbers in this assay, from the lowest: compounds 2, 4 and 3 (each within the scatter of the next); then compound 1.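

In this assay, 3,5-dimethylphenyl at this place lands with the 2,5-dimethylphenyl and 2,4-dimethylphenyl compounds, with a 1.2-fold lower number from compound 3 to compound 4 (0.08 log units; within the scatter) and a 1.1-fold higher number from compound 2 to compound 4 (0.05 log units; within the scatter). Compounds 2, 3 and 4 now form a group of three that the scatter cannot separate, while compound 1 with its 2,3-dimethylphenyl stands apart, as a 7.4-fold lower number from compound 1 to compound 4 (0.87 log units; beyond the scatter) shows, so among these four arrangements of the two methyl groups only that one gives a clearly different number. No measurement at hand explains why the 2,3-dimethylphenyl arrangement differs from the other three.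

Going by these compounds, what a different group at this place would do, such as a pyridine ring or a phenyl ring carrying a carboxylic acid, stays open. On these data alone, it is also open whether the gap between 2,3-dimethylphenyl and the other arrangements would survive a change elsewhere on the shared core.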